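The source may report more compounds than this note shows. Statements on the series, on what has been measured and on what is new or still open speak of the compounds shown alone.

Measured in a functional assay on PC-3 cells (Homo sapiens) for inhibition, read by CellTiter-Glo, with a stated time of 72 h; on this read-out higher numbers stand for lower toxicity in this test and lower numbers for higher toxicity in this test:
- compound 1 `CC1=C(CC(=O)N2CCN(CCCN(C)C)CC2)c2cc(F)ccc2/C1=C\c1ccc([S+](C)[O-])cc1`: > 50000 nM, a limit
- compound 2 `CC1=C(CC(=O)N2CCN(CCCN(C)C)CC2)c2cc(F)ccc2/C1=C\c1nc2ccccc2s1`: 4210 nM
- compound 3 `COC(=O)[C@H](C)NC(=O)CC1=C(C)/C(=C/c2ccc(SC)cc2)c2ccc(F)cc21`: > 50000 nM, a limit

Compound 1 stands at the limit of > 50000 nM in this assay, at which 2 of the 3 values shown sit. Its reading is therefore a limit and not a number.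

The next compound is compound 4 `CC1=C(CC(=O)N(C)CCN(C)S(C)(=O)=O)c2cc(F)ccc2/C1=C\c1ccc([S+](C)[O-])cc1`. It has methyl(2-(methyl(methylsulfonyl)amino)ethyl)amino in place of 4-(3-(dimethylamino)propyl)piperazin-1-yl on a carbonyl carbon.

Going by the values given here, the only measured step is an at least 11-fold lower number from compound 1 to compound 2 (1.07 log units; beyond the scatter). It is large, but it lies on a double-bonded chain carbon bound to a double-bonded ring carbon, which is not the place changed here, so it bears only indirectly. Compound 4 keeps the group of compound 1 at that place. Among the compounds with values here, no single-place step at the carbonyl carbon has been measured.

The nearest guide is compound 3, which has no 4-(3-(dimethylamino)propyl)piperazin-1-yl group and differs from compound 1 in more than one place. Compound 3 gives > 50000 nM, which is also a limit.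

In this assay the expected step is a number no higher from compound 1 to compound 4 (the limit leaves the size open), and no step beyond the scatter is expected in either direction. A reading at the limit is the likeliest outcome.

The estimate for compound 4 is 50000 nM, with an expected range from 25000 nM to 100000 nM.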

Compound 4, half-maximal cytotoxic concentration: 42600 nM
The estimate for compound 4 lay 1.2-fold (0.07 log units) above the measured number; the range from low to high includes it.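

In this assay, going by these compounds alone, the first single-place step at the carbonyl carbon is an at least 1.1-fold lower number from compound 1 to compound 4 (0.06 log units; that floor lies within the scatter), for an exchange of the 4-(3-(dimethylamino)propyl)piperazin-1-yl group, with its six-membered non-aromatic ring, for the ringless methyl(2-(methyl(methylsulfonyl)amino)ethyl)amino group. Compound 1 gives > 50000 nM, which is a limit and not a number, so the true size of this step cannot be read, only its floor: the limit of > 50000 nM in this assay, at which 2 of the 4 values shown sit. The only step shown beyond the scatter therefore remains an at least 11-fold lower number from compound 1 to compound 2 (1.07 log units; beyond the scatter), on a double-bonded chain carbon bound to a double-bonded ring carbon, and the change on the carbonyl carbon has not yet matched it.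

Going by these compounds, it remains open whether the methyl(2-(methyl(methylsulfonyl)amino)ethyl)amino group would shift the number when paired with the group that compound 2 carries on the double-bonded chain carbon, where a true number rather than a limit would serve as the starting point. Also open, on these data alone, is how a morpholine ring or a chain ending in a carboxylic acid on the carbonyl carbon would read in this assay.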